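The source may report more compounds than this note shows. Statements on the series, on what has been measured and on what is new or still open speak of the compounds shown alone.

Compound 1 `Nc1ccccc1NC(=O)c1ccc(COc2ccc(Br)cc2)cc1` was tested in a functional assay on A549 cells (Homo sapiens) for antiproliferative activity, read by CCK-8 assay, with a stated time of 72 h; a higher number here means a weaker inhibitor, a lower number a stronger inhibitor. In this assay compound 1 gives 24400 nM. Among the two compounds for which a number is known, compound 1 stands highest. The nearest is compound 3 `C/C(=N\O)c1ccc(OCc2ccc(C(=O)NO)cc2)cc1`, which in this assay gives 8930 nM, a lower number whose gap to compound 1 lies beyond the usual scatter of repeated measurements. Compound 2 `Nc1ccccc1NC(=O)c1ccc(CN2CCc3cc(Br)ccc32)cc1` belongs to the same set, but in this assay compound 2 gives "not determined" (no result reported), so no result is reported for it.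

Compound 4 `COc1ccc(OCc2ccc(C(=O)Nc3ccccc3N)cc2)cc1` has not yet been measured. It differs from compound 1 in one place: methoxy in place of bromo on an aromatic carbon. The exchange sits on an aromatic carbon of a six-membered aromatic ring of carbon only, para to a large group; read one bond further out, it is 4-bromophenyl to 4-methoxyphenyl.

For the measured compounds named here, no measured pair in this set shows this particular exchange, so its size cannot be taken from the data at hand. Compound 1 already sits at the high end of the numbers seen. The step that is expected is a modest one, a 1.2-fold higher number from compound 1 to compound 4 (0.09 log units; within the scatter), most likely toward a somewhat higher number or none that rises beyond the scatter. Compound 4 is therefore estimated at 30000 nM in this assay, with a range from 10000 nM to 90000 nM.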

Compound 4, half-maximal inhibitory concentration: 5530 nM
For compound 4 the middle estimate is 5.4-fold (0.73 log units) above the measured one, and the stated range ends above it.
By their numbers in this assay, from the lowest: compounds 4 and 3 (each within the scatter of the next); then compound 1.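

This exchange gives the first step read at this position, on an aromatic carbon para to a large group. In this assay, methoxy in place of bromo gives a 4.4-fold lower number from compound 1 to compound 4 (0.64 log units; beyond the scatter) and so shows that the group held here can shift the antiproliferative number of the core of compound 1 beyond the usual scatter, with the stronger result on the methoxy side. The change replaces one heavy atom with two and adds one hydrogen-bond acceptor, but no measurement at hand connects either difference to the step.

Going by these compounds, with only bromo and methoxy read at this position, a single pair gives no trend, and it remains open whether the step belongs to methoxy in particular or whether other groups here would do as well or better. On these data alone, an amine, a hydroxyl group, a chloro group or a longer chain such as ethoxy at the same place could settle this, and it also remains open whether the same exchange would give a similar step on a different core.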